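Fluoro in Place of Tert-Butyl on the Aromatic Ring

The source may hold more compounds than are shown below. What is called first, only, known or untested is meant among the compounds shown, and "the series" means these compounds.

Of the compounds shown here, three sharing one core have been measured in a functional assay on PC-3 cells (Homo sapiens) for cytotoxicity, read by MTT assay, with a stated time of 48 h; a lower number here means a stronger inhibitor, a higher number a weaker inhibitor. Compound 1 `CC1(C)CCC[C@]2(C)[C@@H](CC[C@@](C)(O)/C=C/c3ccccc3)[C@](C)(O)CC[C@@H]12` carries an unsubstituted phenyl on the double-bonded chain carbon and gives 121 nM. Compound 2 `CC1(C)CCC[C@]2(C)[C@@H](CC[C@@](C)(O)/C=C/c3cncc4ccccc34)[C@](C)(O)CC[C@@H]12`, with isoquinolin-4-yl in its place, gives 3900 nM, and compound 3 `CC(C)(C)c1ccc(/C=C/[C@](C)(O)CC[C@@H]2[C@@]3(C)CCCC(C)(C)[C@@H]3CC[C@@]2(C)O)cc1`, carrying a tert-butyl on the aromatic carbon, gives 3800 nM. Compound 3 thus stands second highest of the three numbers, within the scatter of compound 2 and far above compound 1, the gap being a 31-fold higher number from compound 1 to compound 3 (1.50 log units; beyond the scatter).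

The next compound, compound 4 `CC1(C)CCC[C@]2(C)[C@@H](CC[C@@](C)(O)/C=C/c3ccc(F)cc3)[C@](C)(O)CC[C@@H]12`, differs from compound 3 in one place: fluoro in place of tert-butyl on an aromatic carbon. The step most closely bearing on this change is the one that introduced the tert-butyl, a 31-fold higher number from compound 1 to compound 3 (1.50 log units; beyond the scatter); the step of a 32-fold higher number from compound 1 to compound 2 (1.51 log units; beyond the scatter) changed the whole ring and speaks less directly. Since fluoro is a single heavy atom where tert-butyl brought four, compound 4 is expected to sit much nearer compound 1 than compound 3, so that a large drop in number is expected, a 15-fold lower number from compound 3 to compound 4 (1.18 log units; beyond the scatter). Compound 4 is therefore estimated at 250 nM, with a range from 80 nM to 900 nM.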

Compound 4, half-maximal inhibitory concentration: 82 nM
For compound 4 the middle estimate is 3.0-fold (0.48 log units) above the measured one; low and high end bracket the measured number.
By their numbers in this assay, from the lowest: compounds 4 and 1 (each within the scatter of the next); then compounds 3 and 2 (each within the scatter of the next).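

In this assay, the aromatic carbon para to a large group proves to accept a substituent: a 1.5-fold lower number from compound 1 to compound 4 (0.17 log units; within the scatter) lies within the scatter, so fluoro in place of hydrogen leaves the number where the unsubstituted phenyl had it. The earlier compounds shown here showed only a large loss with tert-butyl, and a 46-fold lower number from compound 3 to compound 4 (1.67 log units; beyond the scatter) now ties that loss to tert-butyl itself rather than to any substitution on this carbon, while a 48-fold lower number from compound 2 to compound 4 (1.68 log units; beyond the scatter) shows that a substituted phenyl can also stand far from the isoquinolin-4-yl compound on the double-bonded chain carbon. No measurement here gives a reason for the gap between fluoro and tert-butyl at this carbon.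

The compounds shown leave open where the change sets in between fluoro and tert-butyl, that is, whether a chloro, methoxy or isopropyl group on this carbon would stay within the scatter of compound 1 or move towards compound 3. They also leave open how an amine or a carboxylic acid would fare on the same carbon, and whether fluoro would be accepted equally on another carbon of the ring.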